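A few compounds are considered here, and "the series" means these few. Any claim that something is new, unique, unknown or untested is made for them only; others in the source may bear on it.

The series is examined in a functional assay on MCF7 cells (Homo sapiens) for antiproliferative activity, read by MTT assay, with a stated time of 72 h; on this read-out higher numbers stand for weaker inhibition and lower numbers for stronger inhibition. Compound 1, `COc1ccc2occ(CSC(=S)N3CCCCC3)c(=O)c2c1`, gives in this assay only a limit and not a number, namely > 40000 nM. Compound 2, `CCN(CC)C(=S)SCc1cc(=O)c2ccc(Cl)cc2o1`, likewise returns only a limit, > 25000 nM. Compound 3, `CCOC(=O)c1cc(=O)c2cc(CSC(=S)N(C)c3ccccc3)ccc2o1`, also reaches no number in this assay; its result is the limit > 25000 nM. Compound 3 therefore stands where the other two stand: every value recorded so far is a limit, two of them at the limit of > 25000 nM in this assay, at which 2 of the 3 values shown sit, and one at the limit of > 40000 nM in this assay, at which 1 of the 3 values shown sits, so none of the three compounds can be ordered against another.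

Compound 4, `CCOC(=O)c1cc(=O)c2cc(CSC(=S)N(C(C)C)C(C)C)ccc2o1`, differs from compound 3 in one place: diisopropylamino in place of methyl(phenyl)amino on a thiocarbonyl carbon. The group on the thiocarbonyl carbon changes while the rest of the molecule is kept. Among the compounds with values here, no step between measured compounds exists to gauge such a change, and the measured compounds offer no real potency from which to move. The step that the limit leaves unreadable from compound 3 to compound 4 that is expected is none beyond the scatter, with compound 4 most likely also returning a limit rather than a number. Compound 4 is accordingly estimated at 40000 nM in this assay, within a range from 15000 nM to 100000 nM.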

Compound 4, half-maximal inhibitory concentration: > 25000 nM
Compound 4: only a limit was reported; the forecaster's own chance of this, stated with the estimate: 80%; the middle value is on the limit's open side.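

In this assay compound 4 returns only a limit (> 25000 nM). Within the data shown here, compound 3 also returned only a limit, so no step from compound 3 to compound 4 can be read. The compounds shown leave open whether any of them reaches a measurable potency in this assay, and whether the group on the thiocarbonyl carbon affects it.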